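The source may report more compounds than this note shows. Statements on the series, on what has been measured and on what is new or still open speak of the compounds shown alone.

Measured in a functional assay on ECa-109 cells (Homo sapiens) for cytotoxicity, read by MTT assay, with a stated time of 48 h; on this read-out lower numbers stand for stronger inhibition and higher numbers for weaker inhibition:
- Compound 1 `COc1ccc(-c2c[nH]c(=O)n2-c2cc(OC)c(OC)c(OC)c2)cc1`: > 50000 nM (a limit)
- Compound 2 `COc1ccc(-c2cn(C(C)=O)c(=O)n2-c2cc(OC)c(OC)c(OC)c2)cc1`: > 50000 nM (a limit)

Neither compound gives a number, so compound 2 stands at the limit of > 50000 nM in this assay, at which 2 of the 2 values shown sit. The next structure is compound 3 `COc1ccc(-c2cn(C(C)=O)c(=O)n2-c2cc(OC)c(OC)c(OC)c2)cc1[N+](=O)[O-]`, and it differs from compound 2 as follows: nitro in place of hydrogen on an aromatic carbon. In words, this is nitro in place of hydrogen on an aromatic carbon.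

For the measured compounds named here, only one measured step exists, a step that the two limits leave unreadable from compound 1 to compound 2. That step is acetyl in place of hydrogen on an aromatic nitrogen, a different change at a different place, and it offers no size to carry over. With nothing readable to go on, only a modest move toward stronger inhibition is expected, and compound 3 may also stay at the limit. The step expected in this assay is an at least 1.6-fold lower number from compound 2 to compound 3 (0.22 log units; that floor lies within the scatter), an estimate and no more. Compound 3 is expected at 30000 nM, with an estimated range of 3000 nM to 100000 nM.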

Compound 3, half-maximal inhibitory concentration: 30800 nM
Compound 3: middle estimate off by 1.0-fold (0.01 log units), on the low side; the measured number falls inside the stated range.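

In this assay, compound 3 is the first of the compounds shown to give a number and not a limit, which makes this aromatic carbon, ortho to a methoxy group, the first place where a change has a readable size. Nitro in place of hydrogen there gives an at least 1.6-fold lower number from compound 2 to compound 3 (0.21 log units; that floor lies within the scatter), so the readable size is only a floor. The step from compound 1 to compound 2 cannot be read, and compound 2 stays at a limit: the limit of > 50000 nM in this assay, at which 2 of the 3 values shown sit.

Open, going by these compounds, is whether an amine or a carboxylic acid on the same aromatic carbon would give a lower or a higher number than compound 3. Also open, on these data alone, is whether nitro at this place would give a readable step with hydrogen in place of acetyl on the aromatic nitrogen.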